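Series notes: the step from compound 1 to compound 4

A few compounds are considered here, and "the series" means these few. Any claim that something is new, unique, unknown or untested is made for them only; others in the source may bear on it.

Among the measured compounds shown here, the series shares one core carrying a cyclohexyl group, and the three measured members differ at the substituents on the remaining ring positions. In an ADME assay on Vero cells (Chlorocebus sabaeus) for cytotoxicity, read by resazurin assay, with a stated time of 3 days (a lower number here means a stronger inhibitor, a higher number a weaker inhibitor), compound 1 `CN(C)c1cc2[nH]c(C3CCCCC3)nc2cc1NC(=O)c1ccco1` gives > 100 ug/mL, which is a limit of the assay and not a number. Compound 2 `CCN(CC)c1cc2[nH]c(C3CCCCC3)nc2cc1NC(=O)c1cnccn1` gives > 100 ug/mL in this assay, again only a limit. Compound 3 `CCCNC(=O)Nc1cc2nc(C3CCCCC3)[nH]c2cc1N1CCCC1` likewise sits at > 100 ug/mL in this assay, a limit as well. For the measured compounds named here, compound 1 therefore stands exactly where the other two stand: every value shown is the same limit, as summarised by the limit of > 100 ug/mL in this assay, at which 3 of the 3 values shown sit, and no step between measured compounds can be read off.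

Compound 4 `CCOCCOC(=O)Nc1cc2nc(C3CCCCC3)[nH]c2cc1N(C)C` is not yet measured in this assay. It differs from compound 1 at a single site: 2-ethoxyethoxy in place of furan-2-yl on a carbonyl carbon. Going by the values given here, no pair of measured compounds shows how this kind of change moves the numbers, and with all three values at the limit there is no direction to extrapolate. The expectation is that the step from compound 1 to compound 4 is none beyond the usual scatter, that is a step that the limit leaves unreadable from compound 1 to compound 4, with the result most likely reported again as a limit. For compound 4 in this assay the estimate is 130 ug/mL, between 80 ug/mL and 300 ug/mL.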

Compound 4, half-maximal inhibitory concentration: > 100 ug/mL
Compound 4 was reported as a limit; the forecaster's own chance of this, stated with the estimate: 85%; the middle value does not contradict the limit.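

No step from compound 1 to compound 4 can be read, because both results are limits of the assay and not numbers: the limit of > 100 ug/mL in this assay, at which 4 of the 4 values shown sit.

The compounds shown leave open where any of them would reach a half-maximal effect in this assay, and so whether 2-ethoxyethoxy in place of furan-2-yl on a carbonyl carbon changes the read-out at all.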